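Moving the alkyl chain around the imidazole ring

A few compounds are considered here, and "the series" means these few. Any claim that something is new, unique, unknown or untested is made for them only; others in the source may bear on it.

Compound 1, `Cc1nc(CN2CCN(c3cccc4[nH]c(-c5ccc(C(C)(C)C)cc5)nc34)CC2)c[nH]1`: 28 nM in an assay on isolated protein for displacement of a labelled ligand from Gonadotropin-releasing hormone receptor (Rattus norvegicus); a higher number here means a weaker inhibitor, a lower number a stronger inhibitor
Compound 2, `CCc1nc(CN2CCN(c3cccc4[nH]c(-c5ccc(C(C)(C)C)cc5)nc34)CC2)cn1C`: 78 nM in this assay
Compound 3, `CCCCc1nc(CN2CCN(c3cccc4[nH]c(-c5ccc(C(C)(C)C)cc5)nc34)CC2)cn1C`: 58 nM in this assay

Compound 3 has the second highest of the three numbers. Its nearest neighbour is compound 2: a 1.3-fold lower number from compound 2 to compound 3 (0.13 log units; within the scatter), so those two cannot be told apart. Against compound 1 the gap is larger: a 2.1-fold higher number from compound 1 to compound 3 (0.32 log units; beyond the scatter).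

Compound 4, `CCCn1cc(CN2CCN(c3cccc4[nH]c(-c5ccc(C(C)(C)C)cc5)nc34)CC2)nc1C`, keeps the shared core of compound 3 and changes only the imidazole: 2-methyl-1-propyl-1H-imidazol-4-yl in place of 2-butyl-1-methyl-1H-imidazol-4-yl on a saturated chain carbon bound to an amine nitrogen in a ring. In effect the longer chain moves from the ring carbon to the ring nitrogen, while the methyl moves the other way.

Among the compounds with values here, two measured steps bear on this. Both start from compound 1, whose ring nitrogen carries hydrogen: a 2.8-fold higher number from compound 1 to compound 2 (0.44 log units; beyond the scatter) and a 2.1-fold higher number from compound 1 to compound 3 (0.32 log units; beyond the scatter). Each of these puts a methyl on the ring nitrogen together with a longer chain on the ring carbon, and both raise the number modestly. The step of a 1.3-fold lower number from compound 2 to compound 3 (0.13 log units; within the scatter) shows that lengthening the chain on the ring carbon by itself does little. Within the data shown here, no measured step places a chain longer than methyl on the ring nitrogen, so that part of the change is untested.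

Compound 4 is therefore expected to stay close to compound 3, with a 1.0-fold higher number from compound 3 to compound 4 (0.01 log units; within the scatter), and its estimated value in this assay is 60 nM, within a range of 25 nM to 150 nM.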

Compound 4, half-maximal inhibitory concentration: 41 nM
The estimate for compound 4 lay 1.5-fold (0.17 log units) above the measured number; measured number inside the range.
By their numbers in this assay, from the lowest: compounds 1, 4, 3 and 2 (each within the scatter of the next, the first and the last beyond it).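

Moving to a chain longer than methyl on the ring nitrogen is tolerated here: in this assay, propyl in place of hydrogen on an aromatic nitrogen gives a 1.5-fold higher number from compound 1 to compound 4 (0.17 log units; within the scatter), so these two cannot be told apart, whereas compound 2 and compound 3, with methyl on that nitrogen and a longer chain on the ring carbon, each lie beyond the scatter from compound 1. Exchanging 2-butyl-1-methyl-1H-imidazol-4-yl for 2-methyl-1-propyl-1H-imidazol-4-yl gives a 1.4-fold lower number from compound 3 to compound 4 (0.15 log units; within the scatter), and exchanging 2-ethyl-1-methyl-1H-imidazol-4-yl for the same group gives a 1.9-fold lower number from compound 2 to compound 4 (0.28 log units; within the scatter), so compound 4 cannot be separated from either of these compounds, and this position accepts the chain on either atom without a clear change in this assay. No supporting measurement is available to explain these small differences.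

From the compounds shown here alone, whether a butyl or still longer chain on the ring nitrogen would also fit remains open. So does the effect of a carboxylic acid or an amine at the end of that chain.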